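The source may hold more compounds than are shown below. What is called first, only, known or untested is meant among the compounds shown, and "the series" means these compounds.

Measured so far:
compound 1 `CN(C)CCn1cnnc1-c1cc(Oc2ccc(NC(=O)Nc3ccc(F)c(F)c3)cc2F)ccn1` — > 50000 nM
compound 2 `CN(C)CCCn1cnnc1-c1cc(Oc2ccc(NC(=O)Nc3cccc(C(F)(F)F)c3)cc2F)ccn1` — 13300 nM

In a functional assay on MDA-MB-231 cells (Homo sapiens) for antiproliferative activity, read by MTT assay, with a stated time of 72 h (a higher number here means a weaker inhibitor, a lower number a stronger inhibitor), compound 2 gives 13300 nM, the only number shown in the set. For compound 1 the value > 50000 nM is a limit of the assay, not a number. Compound 3 `CN(C)CCCn1cnnc1-c1cc(Oc2ccc(NC(=O)Nc3ccc(F)c(F)c3)cc2F)ccn1` has not yet been measured; it differs from compound 2 by 3,4-difluorophenyl in place of 3-(trifluoromethyl)phenyl on an amide-type nitrogen. Compound 1 also carries the 3,4-difluorophenyl and sits at the limit of > 50000 nM in this assay, at which 1 of the 2 values shown sits. Going by the values given here, no measured step isolates this change on its own. A weakening beyond the scatter is expected, a 2.4-fold higher number from compound 2 to compound 3 (0.38 log units; beyond the scatter). Compound 3 is estimated at 32000 nM, with a range from 12000 nM to 80000 nM.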

Compound 3, half-maximal inhibitory concentration: 25300 nM
For compound 3 the middle estimate is 1.3-fold (0.10 log units) above the measured one; measured number inside the range.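

In this assay, 3,4-difluorophenyl in place of 3-(trifluoromethyl)phenyl on an amide-type nitrogen gives a 1.9-fold higher number from compound 2 to compound 3 (0.28 log units; within the scatter), so this exchange is not resolved at this position. (Dimethylamino)methyl in place of dimethylamino on a saturated chain carbon gives an at least 1.9-fold lower number from compound 1 to compound 3 (0.29 log units; that floor lies within the scatter), so even the floor of this step does not separate the two chains. The reading for compound 1 is a limit of the assay, not a number: the limit of > 50000 nM in this assay, at which 1 of the 3 values shown sits.

Going by these compounds, the true size of the chain step remains open. Also open, on these data alone, is whether a morpholine in place of dimethylamino, or a chlorine on the phenyl, would move the number in this assay beyond the scatter.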